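This account rests on a few compounds, and the source may have more. Where it says the series, first, only, none or still open, it means among the compounds named here.

Compound 1, `CC1=CC[C@H](C(C)(C)N=C=S)CC1`, gives 4000 nM in a functional assay on K562 cells (Homo sapiens) for inhibition, read by sulforhodamine B assay, with a stated time of 48 h; on this read-out lower numbers stand for stronger inhibition of growth and higher numbers for weaker inhibition of growth.
Compound 2, `CC1=CC[C@H](C(C)(C)NC(=S)N/N=C/c2ccc(N(C)C)cc2)CC1`, gives 22600 nM in this assay.
Compound 3, `CC1=CC[C@H](C(C)(C)NC(=S)N/N=C/c2ccc(F)cc2)CC1`, gives > 100000 nM in this assay, which is a limit of the assay and not a number.

Compound 3 therefore stands at the weak end of what has been measured: its result is only a limit, (the limit of > 100000 nM in this assay, at which 1 of the 3 values shown sits), so its true position above that point is not known. Compound 4, `CC1=CC[C@H](C(C)(C)NC(=S)N/N=C/c2cccs2)CC1`, differs from compound 3 in one place: thiophen-2-yl in place of 4-fluorophenyl on a carbon with a double bond to nitrogen. For the measured compounds named here, the only measured step that concerns this part of the molecule is an at least 4.4-fold higher number from compound 2 to compound 3 (0.64 log units; beyond the scatter), a change of a substituent on the same aromatic ring, not an exchange of the ring itself, and it ends at a limit. Going by the values given here, no measured step exchanges the six-membered ring for a five-membered one, so the direction and size of the change in this assay cannot be read from the data. Compound 4 is expected to give about 60000 nM, between 15000 nM and 200000 nM, which means an estimated step of an at least 1.6-fold lower number from compound 3 to compound 4 (0.22 log units; that floor lies within the scatter).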

Compound 4, concentration for 50% growth inhibition: 17600 nM
Compound 4: middle estimate off by 3.4-fold (0.53 log units), on the high side, and the stated range covers the measured number.
By their numbers in this assay, from the lowest: compound 1; then compounds 4 and 2 (each within the scatter of the next). At a limit, above all of these: compound 3.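

Exchanging the ring itself at this place, on the carbon with a double bond to nitrogen, moves the result beyond the scatter in this assay: the measured change is an at least 5.6-fold lower number from compound 3 to compound 4 (0.75 log units; beyond the scatter), whereas the earlier step changed only a substituent on the ring. The starting point of this step is a limit, so its true size is not known: the limit of > 100000 nM in this assay, at which 1 of the 4 values shown sits.

Compound 4 gives 17600 nM and compound 2 gives 22600 nM, values within the scatter of each other, so a measurable value at this place does not require the dimethylamino group.

Going by these compounds, whether the change follows the sulfur or the five-membered ring remains open, and a furan-2-yl or unsubstituted phenyl group at this place would help separate the two. Also open, on these data alone, is how an amine or a carboxylic acid on the thiophen-2-yl ring would read.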